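A few compounds are considered here, and "the series" means these few. Any claim that something is new, unique, unknown or untested is made for them only; others in the source may bear on it.

Compound 1 `CN(C)C(=O)c1cc2cnc(Nc3ccc(NC(=O)C4(C(=O)Nc5ccc(F)cc5)CC4)cc3)nc2n1C1CCCC1`: 105%
Compound 2 `CN(C)C(=O)c1cc2cnc(Nc3ccc(NC(=O)C4(C(=O)Nc5ccc(Cl)c(C(F)(F)F)c5)CC4)cc3)nc2n1C1CCCC1`: 55.8%

In a functional assay on T47D cells (Homo sapiens) for inhibition, read by CCK-8 assay, with a stated time of 72 h, tested at 10 uM (on this read-out lower numbers stand for less inhibition of growth and higher numbers for more inhibition of growth at the one concentration tested), compound 1 gives 105%, the higher of the two numbers; compound 2 gives 55.8%. Among the measured compounds shown here, the one measured step, a number 49.2 percentage points lower from compound 1 to compound 2 (beyond the scatter), concerns a different change on the same amide-type nitrogen and bears on the present step only loosely, as a sign that this position is sensitive. Compound 3 `CN(C)C(=O)c1cc2cnc(Nc3ccc(NC(=O)C4(C(=O)Nc5ccc(O)cc5)CC4)cc3)nc2n1C1CCCC1` differs from compound 1 by hydroxy in place of fluoro on an aromatic carbon. For the measured compounds named here, no measured step tests hydroxy here. A small step, a number 15 percentage points lower from compound 1 to compound 3 (beyond the scatter), is expected, downward if any. Compound 3 is estimated at 90%, in the range 60% to 105%.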

Compound 3, percent growth inhibition at one concentration: 95.8%
For compound 3 the middle estimate is 5.8 percentage points below the measured one, and the stated range covers the measured number.
By their numbers in this assay, from the lowest: compound 2; then compounds 3 and 1 (each within the scatter of the next).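

In this assay, hydroxy in place of fluoro on the aromatic carbon para to a large group gives a number 9.2 percentage points lower from compound 1 to compound 3 (within the scatter), so this position accepts either group without a change beyond the scatter. With 4-hydroxyphenyl in place of 4-chloro-3-(trifluoromethyl)phenyl the step is a number 40 percentage points higher from compound 2 to compound 3 (beyond the scatter), which leaves compound 2 as the low member against both compound 1 and compound 3. No measurement at hand accounts for these numbers.

Open, on these data alone, is whether an amine, a carboxylic acid or methoxy on this carbon would keep the growth inhibition. Also open, as far as these compounds go, is whether the chloro or the trifluoromethyl alone accounts for the lower number of compound 2.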